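Hydrazone aryl swap: dihydroxyphenyl to hydroxy-methoxyphenyl

A few compounds are considered here, and "the series" means these few. Any claim that something is new, unique, unknown or untested is made for them only; others in the source may bear on it.

Compound 3 `COc1ccccc1-c1nnc(-c2ccc(C(=O)N/N=C/c3cccc(O)c3O)cc2)o1` gives 102000 nM in an ADME assay on THP-1 cells (Homo sapiens) for cytotoxicity (a higher number here means a weaker inhibitor, a lower number a stronger inhibitor), and holds the lowest of the three numbers in hand. Compound 1 `COc1ccccc1-c1nnc(-c2ccc(C(=O)N/N=C/c3ccc([N+](=O)[O-])cc3)cc2)o1` gives 203000 nM in this assay, and compound 2 `COc1ccccc1-c1nnc(-c2ccc(C(=O)N/N=C/c3ccc(F)cc3)cc2)o1` gives 427000 nM. The step of a 2.0-fold lower number from compound 1 to compound 3 (0.30 log units; within the scatter) lies within the scatter, so compound 3 and compound 1 cannot be told apart on these numbers; the step of a 4.2-fold lower number from compound 2 to compound 3 (0.62 log units; beyond the scatter) is a modest drop, and a 2.1-fold higher number from compound 1 to compound 2 (0.32 log units; beyond the scatter) a modest rise.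

Compound 4 `COc1ccc(O)c(/C=N/NC(=O)c2ccc(-c3nnc(-c4ccccc4OC)o3)cc2)c1` remains unmeasured. The change is 2-hydroxy-5-methoxyphenyl in place of 2,3-dihydroxyphenyl on a carbon with a double bond to nitrogen. Only the two steps into compound 3 touch the same position, and each moved the number by a modest amount at most. Among the measured compounds shown here, no measured pair shows this particular exchange of one hydroxyl for a methoxy, so the direction is uncertain. A small step, at most modest and if anything towards a higher number, is expected: a 1.5-fold higher number from compound 3 to compound 4 (0.17 log units; within the scatter) is the estimated step. Compound 4 is therefore estimated at 150000 nM in this assay, with a range from 60000 nM to 400000 nM.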

Compound 4, half-maximal inhibitory concentration: 303000 nM
Beside the measured number, compound 4's estimate is 2.0-fold (0.31 log units) below it, within the range that was stated.
By their numbers in this assay, from the lowest: compounds 3, 1, 4 and 2 (each within the scatter of the next, the first and the last beyond it).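

In this assay, 2-hydroxy-5-methoxyphenyl in place of 2,3-dihydroxyphenyl on a carbon with a double bond to nitrogen gives a 3.0-fold higher number from compound 3 to compound 4 (0.47 log units; beyond the scatter), so this exchange, with 1 hydrogen-bond donor entering where 2 hydrogen-bond donors leave, registers as a modest rise beyond the scatter. The steps of a 1.4-fold lower number from compound 2 to compound 4 (0.15 log units; within the scatter) and a 1.5-fold higher number from compound 1 to compound 4 (0.17 log units; within the scatter) both lie within the scatter, so at this position 2-hydroxy-5-methoxyphenyl cannot be told apart from 4-fluorophenyl or 4-nitrophenyl. Nothing at hand accounts for these steps.

Still open, as far as these compounds go, is whether the rise follows the lost hydroxyl or the added methoxy, as compound 4 carries both changes at once. Also open, from the compounds shown here alone, is how the number responds at this position to an aryl group bearing an amine or a carboxylic acid.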